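The compounds below may be only part of what the source reports. "The series", "measured", "known", "first", "only" and "open" are said of these compounds alone.

Measured so far in a functional assay on A549 cells (Homo sapiens) for antiproliferative activity, read by spectrophotometry, with a stated time of 2 days; a higher number here means a weaker inhibitor of growth, a lower number a stronger inhibitor of growth:
Compound 1 `COc1ccc(C(F)(F)F)cc1Nc1ncc(C(F)(F)F)c(N2Cc3cccc(N(C)S(C)(=O)=O)c3C2)n1`: > 30000 nM, a limit and not a number.
Compound 2 `Cc1cc(C)cc(Nc2ncc(C(F)(F)F)c(N3Cc4cccc(N(C)S(C)(=O)=O)c4C3)n2)c1`: > 30000 nM, a limit and not a number.
Compound 3 `Cc1ccc(Nc2ncc(C(F)(F)F)c(N3Cc4cccc(N(C)S(C)(=O)=O)c4C3)n2)c(C)c1`: 20700 nM.

Of these three, only compound 3 has an actual number, 20700 nM. The other two results are limits, so its rank against them cannot be settled. Compound 4 `COc1cc(Nc2ncc(C(F)(F)F)c(N3Cc4cccc(N(C)S(C)(=O)=O)c4C3)n2)cc(C(F)(F)F)c1` keeps the shared core and differs from compound 3 in one place: 3-methoxy-5-(trifluoromethyl)phenyl in place of 2,4-dimethylphenyl on a nitrogen on an aromatic ring. Here 3-methoxy-5-(trifluoromethyl)phenyl takes the place of 2,4-dimethylphenyl on a nitrogen on an aromatic ring.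

The measured steps at this same place are the guide. One is an at least 1.4-fold lower number from compound 1 to compound 3 (0.16 log units; that floor lies within the scatter), and the other is an at least 1.4-fold lower number from compound 2 to compound 3 (0.16 log units; that floor lies within the scatter). Both are only floors, and neither shows a gap beyond the scatter. The third, a step that the two limits leave unreadable from compound 1 to compound 2, gives no size at all. Compound 1 is the nearest comparison, since its 2-methoxy-5-(trifluoromethyl)phenyl group has the same named substituents as the entering group, and it gives > 30000 nM, which is a limit. The series as a whole sits close to the limit of > 30000 nM in this assay, at which 2 of the 3 values shown sit. A small move toward weaker growth inhibition therefore seems likely, and the assay may report only a limit. The expected change is a 1.4-fold higher number from compound 3 to compound 4 (0.16 log units; within the scatter). For compound 4, the estimated value is 30000 nM, with an expected range of 14000 nM to 60000 nM.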

Compound 4, concentration for 50% growth inhibition: > 30000 nM
Compound 4: no number, only a limit; the forecaster's own chance of this, stated with the estimate: 60%; the middle value sits exactly at the limit.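

As far as these compounds go, putting 3-methoxy-5-(trifluoromethyl)phenyl in place of 2,4-dimethylphenyl on the nitrogen gives an at least 1.4-fold higher number from compound 3 to compound 4 (0.16 log units; that floor lies within the scatter) in this assay, so this change cannot be told apart from no change at all, and its true size remains unknown. What is new is that a second phenyl group carrying methoxy and trifluoromethyl, after the 2-methoxy-5-(trifluoromethyl)phenyl of compound 1, also yields only a limit, and the steps among compound 1, compound 2 and compound 4 cannot be read. Compound 3 remains the only compound with an actual number, and the results now crowd further against the top of the measurable range: the limit of > 30000 nM in this assay, at which 3 of the 4 values shown sit.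

From the compounds shown here alone, all four compounds carry a substituted phenyl on this nitrogen, and how a phenyl bearing an amine or a carboxylic acid, or a longer chain in place of the phenyl ring, would behave remains open. Also open, going by these compounds, is whether any group at this place can bring the number clearly below that of compound 3, which would be needed before a real trend could be read here.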